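Swapping fluoro for methoxy without a number to start from

This account rests on a few compounds, and the source may have more. Where it says the series, first, only, none or still open, it means among the compounds named here.

Within the data shown here, only one compound in this small set has a measured number so far. In a functional assay on HCT-116 cells (Homo sapiens) for cytotoxicity (on this read-out lower numbers stand for an effect already at smaller amounts and higher numbers for an effect only at larger amounts of compound), compound 1 `CC(=O)SCC(=O)c1ccc(NS(=O)(=O)c2ccccc2)cc1` gives 15400 nM. Compound 2 `CC(=O)SCC(=O)c1ccc(NS(=O)(=O)c2cccc(F)c2)cc1` offers no such anchor: in this assay compound 2 stands at "not determined" (no result reported), so it holds no place on the scale. Compound 3 `COc1cccc(S(=O)(=O)Nc2ccc(C(=O)CSC(C)=O)cc2)c1` is the next to be tested. The structural change is methoxy in place of fluoro on an aromatic carbon, which means methoxy in place of fluoro on an aromatic carbon, meta to a large group. Among the measured compounds shown here, no measured step shows what such a change does here, so the expectation is modest: no shift beyond the usual scatter, in either direction, from the level of compound 1 at 15400 nM. Compound 3 is expected at about 15000 nM, with an estimated range of 5000 nM to 45000 nM.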

Compound 3, half-maximal effective concentration: 2600 nM
Estimate against measurement, compound 3: 5.8-fold (0.76 log units) above; the whole stated range lies above it.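

In this assay this ring position turns out to respond to a change: replacing the hydrogen on this aromatic carbon with methoxy, meta to a large group, gives a 5.9-fold lower number from compound 1 to compound 3 (0.77 log units; beyond the scatter) on an otherwise unchanged core. Among these compounds, the swap of fluoro for methoxy itself cannot be read, as compound 2 has no number, so the only usable comparison is with the hydrogen of compound 1. Nothing measured here explains why the number moves.

Where fluoro would stand relative to hydrogen and methoxy remains open, so the effect of the two groups cannot yet be ranked. From the compounds shown here alone, it is also open whether the change is specific to methoxy, or whether a hydroxyl, an amine or a longer chain such as ethoxy on the same carbon would shift the number similarly.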